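Replacing a glycyl-alanine chain with a butanoyl-glycine chain

The source may report more compounds than this note shows. Statements on the series, on what has been measured and on what is new or still open speak of the compounds shown alone.

Measured so far:
compound 1, `NC(C(=O)NCC(=O)Nc1ccc(Cl)cc1C(=O)c1ccccc1)c1ccccc1`, > 100 mg/kg;
compound 2, `CN(C)CC(=O)NCC(=O)N(C)c1ccc(Cl)cc1C(=O)c1ccccc1Cl`, 26 mg/kg;
compound 3, `CC(NC(=O)CN)C(=O)N(C)c1ccc(Cl)cc1C(=O)c1ccccc1Cl`, 8.5 mg/kg.

In a functional assay on the whole organism with Mus musculus as the target, in the rotarod test (a lower number here means that less compound is needed, a higher number that more compound is needed for the effect), compound 1 gives only a limit, > 100 mg/kg, and not a number. Compound 2 gives 26 mg/kg in this assay, and compound 3 gives 8.5 mg/kg, the lowest of the two numbers shown. Going by the values given here, the one step between neighbouring compounds, a 3.1-fold lower number from compound 2 to compound 3 (0.49 log units; beyond the scatter), is a modest change.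

Compound 4, `CCCC(=O)NCC(=O)N(C)c1ccc(Cl)cc1C(=O)c1ccccc1Cl`, is not yet measured. It differs from compound 3 in one place: ((propylcarbonyl)amino)methyl in place of 1-(((aminomethyl)carbonyl)amino)ethyl on a carbonyl carbon. Among the compounds with values here, no measured step removes an amino group from this chain and puts a plain propyl chain in its place, so the step from compound 2 to compound 3 is only a rough guide to how sensitive this part of the molecule is. A modest rise in the number, in the direction of less potency, is expected for compound 4, namely a 2.9-fold higher number from compound 3 to compound 4 (0.47 log units; beyond the scatter). Compound 4 is therefore estimated at 25 mg/kg, in a range from 8 mg/kg to 80 mg/kg.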

Compound 4, dose for half-maximal effect: 55.2 mg/kg
Estimate against measurement, compound 4: 2.2-fold (0.34 log units) below, within the range that was stated.
By their numbers in this assay, from the lowest: compound 3; then compound 2; then compound 4. At a limit, above all of these: compound 1.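

In this assay, the amine on this chain appears to matter: the plain propyl-ended chain gives a 6.5-fold higher number from compound 3 to compound 4 (0.81 log units; beyond the scatter), and ethyl in place of dimethylamino gives a 2.1-fold higher number from compound 2 to compound 4 (0.33 log units; beyond the scatter), so compound 4 needs more compound than either amine-bearing neighbour. Going by these compounds alone, the earlier step only swapped one amine-bearing chain for another, so these are the first steps to show what happens at this position when the chain carries no amine at all. Nothing among the data shown explains why the number rises.

As far as these compounds go, it remains open whether an amine is specifically required, or whether a hydroxyl group or a carboxylic acid on the chain would serve as well. Also open, from the compounds shown here alone, is how a longer chain ending in an amine would compare with compound 3.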